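From hydroxy to pyridin-2-yl under a cytotoxicity limit

The source may report more compounds than this note shows. Statements on the series, on what has been measured and on what is new or still open speak of the compounds shown alone.

Compound 1 `CCOC(=O)c1cc(/C=C/c2cccc(C(C)C)c2)on1` and compound 2 `CCOC(=O)c1cc(/C=C/c2cccc(O)c2)on1` share a core and differ in one group. In an ADME assay on Vero cells (Chlorocebus sabaeus) for cytotoxicity, with a stated time of 72 h (a lower number here means a stronger inhibitor, a higher number a weaker inhibitor), compound 1 gives > 128000 nM, which is a limit of the assay and not a number. In this assay compound 2 gives > 128000 nM, again only a limit. Compound 2 therefore stands at the limit of > 128000 nM in this assay, at which 2 of the 2 values shown sit.

Compound 3 `CCOC(=O)c1cc(/C=C/c2cccc(-c3ccccn3)c2)on1` carries pyridin-2-yl in place of hydroxy on an aromatic carbon, meta to a large group: pyridin-2-yl in place of hydroxy on an aromatic carbon.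

Going by the values given here, the only measured change, hydroxy in place of isopropyl, is a step that the two limits leave unreadable from compound 1 to compound 2, so it offers no size to carry over. Only a cautious expectation follows: little change, with any readable shift going toward lower numbers. The expected move is an at least 1.4-fold lower number from compound 2 to compound 3 (0.15 log units; that floor lies within the scatter). Compound 3 is estimated at 90000 nM, with an expected range from 25000 nM to 128000 nM.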

Compound 3, half-maximal inhibitory concentration: 113000 nM
Estimate against measurement, compound 3: 1.3-fold (0.10 log units) below, and the stated range covers the measured number.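

In this assay, going by these compounds alone, compound 3 is the only one of the three compounds whose reading is a number and not a limit, which gives this position its first readable value. Read against hydroxy, the change to pyridin-2-yl is an at least 1.1-fold lower number from compound 2 to compound 3 (0.05 log units; that floor lies within the scatter), and read against isopropyl, it is an at least 1.1-fold lower number from compound 1 to compound 3 (0.05 log units; that floor lies within the scatter); a whole six-membered aromatic ring on this carbon therefore leaves the reading near the top of the range that can be measured. The other two compounds remain at a limit of the assay, not a number: the limit of > 128000 nM in this assay, at which 2 of the 3 values shown sit.

As far as these compounds go, the step between compound 1 and compound 2 cannot be read, and the true size of both new steps stays unknown. From the compounds shown here alone, whether an amine or a carboxylic acid on this same carbon would give a number well clear of that limit remains open.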